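The source may hold more compounds than are shown below. What is called first, only, known or untested is meant among the compounds shown, and "the series" means these compounds.

Compounds measured so far in a functional assay on Shh Light II cells (Mus musculus) for inhibition, read by a luciferase reporter; on this read-out higher numbers stand for weaker inhibition and lower numbers for stronger inhibition:
compound 1 `C[C@@H]1C[C@H](c2nc(-c3ccc4ccccc4n3)no2)CCN1C(=O)Nc1ccccc1Cl`: 2400 nM
compound 2 `C[C@H]1C[C@H](c2nc(-c3ccc4ccccc4n3)no2)CCN1C(=O)Nc1ccccc1Cl`: 900 nM
compound 3 `O=C(Nc1ncccc1Cl)N1CCC(c2nc(-c3ccc4ccccc4n3)no2)CC1`: 2800 nM

Compound 3 carries the highest of the three numbers in this assay. Against compound 1 the gap is within the scatter; against compound 2 it is beyond the scatter, compound 2 giving the lowest number of the set. Among the compounds with values here, the only step measured between single-change neighbours is a 2.7-fold lower number from compound 1 to compound 2 (0.43 log units; beyond the scatter), and it rests on the fact that compounds 1 and 2 differ only in the configuration as drawn alone.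

Compound 4 `O=C(N1CCC(c2nc(-c3ccc4ccccc4n3)no2)CC1)N1CCCc2ccccc21` is not yet measured. It differs from compound 3 in one place: 1,2,3,4-tetrahydroquinolin-1-yl in place of (3-chloropyridin-2-yl)amino on a carbonyl carbon

Within the data shown here, no measured step speaks to this change. The stereochemical step between compound 1 and compound 2 concerns a ring carbon of the shared core, not the urea substituent, so it gives no direction here. The expected step in this assay is therefore open, with no clear basis for a shift beyond the scatter in either direction; the expected step is a 1.1-fold higher number from compound 3 to compound 4 (0.03 log units; within the scatter). Compound 4 is expected to give about 3000 nM, in a range from 800 nM to 12000 nM.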

Compound 4, half-maximal inhibitory concentration: 2300 nM
For compound 4 the middle estimate is 1.3-fold (0.12 log units) above the measured one, and the stated range covers the measured number.
By their numbers in this assay, from the lowest: compound 2; then compounds 4, 1 and 3 (each within the scatter of the next).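

In this assay the exchange of (3-chloropyridin-2-yl)amino for 1,2,3,4-tetrahydroquinolin-1-yl on the carbonyl carbon gives a 1.2-fold lower number from compound 3 to compound 4 (0.09 log units; within the scatter) and so leaves the number unchanged within the scatter. For this pair, the position accepts an entering group with 0 hydrogen-bond donors and 0 hydrogen-bond acceptors in place of one with 1 of each, and a ring of carbon only in place of a chlorinated aromatic ring with 1 hetero atom, with no shift that can be read. Within the data shown here, nothing measured so far explains this result.

Still open, from the compounds shown here alone, is whether morpholin-4-yl or a plain dimethylamino group on the same carbonyl carbon would keep the number in this range. Also open, going by these compounds, is whether the ring-carbon configuration of compound 2 would give a comparable step when 1,2,3,4-tetrahydroquinolin-1-yl stands on the carbonyl carbon.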